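A few compounds are considered here, and "the series" means these few. Any claim that something is new, unique, unknown or untested is made for them only; others in the source may bear on it.

Compound 3 `CCCOC(=O)C1=C(C)NC(=S)NC1c1ccsc1` carries a propyl ester on the shared core and in an assay on membranes from HEK293 cells for displacement of a labelled ligand from adenosine receptor A2b (Homo sapiens), read by scintillation counting, with a stated time of 30 min, tested at 1 uM (a higher number here means more inhibition at the concentration tested (going by the name of the read-out), a lower number less inhibition), compound 3 gives 26%. That number stands level, at the digits printed, with compound 1 `CC1=C(C(=O)OC(C)(C)C)C(c2cccs2)NC(=S)N1`, which in this assay gives 26%, and the two together make up the lowest of the three numbers measured. Compound 2 `COC(=O)C1=C(C)NC(=S)NC1c1ccsc1`, the methyl ester, gives 38% in this assay and so sits furthest from compound 3. For the measured compounds named here, the one step that bears on the ester chain, a number 12 percentage points lower from compound 2 to compound 3 (beyond the scatter), went beyond the scatter as the chain grew.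

Compound 4 `CC1=C(C(=O)OC(C)(C)C)C(c2ccsc2)NC(=S)N1` differs from compound 3 in one place: tert-butyl in place of propyl on an oxygen next to a carbonyl group. Going by the values given here, the only measured step on that chain lowered the number when it grew longer, and compound 1, which already carries tert-butyl, sits at 26%, so no step beyond the scatter is expected here. The expected step is a number 1 percentage points lower from compound 3 to compound 4 (within the scatter). Compound 4 is therefore estimated to give 25% in this assay, within a range from 12% to 38%.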

Compound 4, a percentage reported as inhibition, at one concentration (the size of the read-out at that concentration, not a potency): 26%
Estimate against measurement, compound 4: 1 percentage points below; the range from low to high includes it.
By their numbers in this assay, from the lowest: compounds 1, 3 and 4 (each within the scatter of the next); then compound 2.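

Swapping the branched chain for the straight one does not separate the two esters in this assay: no change at the digits printed from compound 3 to compound 4 (within the scatter). The tert-butyl ester also parts from the methyl ester, a number 12 percentage points lower from compound 2 to compound 4 (beyond the scatter), which matches the printed step for the propyl ester, a number 12 percentage points lower from compound 2 to compound 3 (beyond the scatter), so among these three esters on the thiophen-3-yl series, only the methyl ester stands apart. The attachment of the thiophene can now be read as well, with the tert-butyl ester held constant: no change at the digits printed from compound 1 to compound 4 (within the scatter), so thiophen-3-yl in place of thiophen-2-yl on a saturated ring carbon leaves the number where it was.

Nothing at hand explains why the methyl ester stands apart from the other esters. On these data alone, whether a longer chain on the ester oxygen, a carboxylic acid or an amide in place of the ester, or a phenyl ring in place of the thiophene would move the number remains open.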